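Two Limits and an Ethoxy Swap

A few compounds are considered here, and "the series" means these few. Any claim that something is new, unique, unknown or untested is made for them only; others in the source may bear on it.

Measured in a functional assay on HL-60 cells (Homo sapiens), read by colorimetric assay, with a stated time of 24 h; a higher number here means a weaker inhibitor, a lower number a stronger inhibitor:
Compound 1 `Nc1nc(Cl)nc2c1ncn2[C@@H]1O[C@H]([C@H](O)CO)[C@@H](O)[C@H]1O`: > 100000 nM
Compound 2 `CNc1nc(Cl)nc2c1ncn2[C@@H]1O[C@H]([C@H](O)CO)[C@@H](O)[C@H]1O`: > 100000 nM

Both entries are assay limits, not numbers. In this assay compound 2 stands at > 100000 nM, which is a limit. Compound 3 `CCOc1nc(Cl)nc2c1ncn2[C@@H]1O[C@H]([C@H](O)CO)[C@@H](O)[C@H]1O` carries ethoxy in place of methylamino on an aromatic carbon. Among the compounds with values here, the only measured step, a step that the two limits leave unreadable from compound 1 to compound 2, bears on this change but gives no size, and the series so far shows only (the limit of > 100000 nM in this assay, at which 2 of the 2 values shown sit). No readable step in either direction is therefore expected in this assay, and another limit is likely. The expected step is a number no higher from compound 2 to compound 3 (the limit leaves the size open). For compound 3 the estimated value is 100000 nM, within an expected range from 40000 nM to 100000 nM.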

Compound 3, half-maximal inhibitory concentration: > 100000 nM
Compound 3 gave a limit, no number (the forecaster's own chance of this, stated with the estimate: 75%); the middle value lies on the limit itself.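

Within the data shown here, no step among compound 1, compound 2 and compound 3 can be read, and the series shows only this: the limit of > 100000 nM in this assay, at which 3 of the 3 values shown sit. The compounds shown leave open how amino, methylamino and ethoxy compare in this assay.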